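A few compounds are considered here, and "the series" means these few. Any claim that something is new, unique, unknown or untested is made for them only; others in the source may bear on it.

Compound 2 `CC(C)Cc1cc(CNS(=O)(=O)c2ccccc2)nn1-c1ccccc1` gives the lower of the two numbers measured in an assay on isolated protein for binding affinity to 5-hydroxytryptamine receptor 6 (Homo sapiens), tested at 10 uM; a higher number here means more inhibition at the concentration tested (going by the name of the read-out), a lower number less inhibition: compound 2 gives 11.3%, while compound 1 `CC(C)Cc1cc(CNS(=O)(=O)c2ccc(C(C)(C)C)cc2)nn1-c1ccccc1` gives 51.1%. Among the compounds with values here, the one step that separates them, a number 39.8 percentage points lower from compound 1 to compound 2 (beyond the scatter), is the only guide available here, and it shows that what sits on the ring attached to the sulfonyl sulfur can move the read-out a long way.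

Compound 3 `Cc1c(Cl)cccc1S(=O)(=O)NCc1cc(CC(C)C)n(-c2ccccc2)n1` differs from compound 2 by 3-chloro-2-methylphenyl in place of phenyl on a sulfonyl sulfur. Within the data shown here, since the step from compound 1 to compound 2 lost ground when a group on that ring was removed, putting groups back onto that ring is expected to recover some of it, though the new ring is not the same as the one in compound 1, so a smaller gain is expected. The expected step is a number 18.7 percentage points higher from compound 2 to compound 3 (beyond the scatter), and compound 3 is estimated at 30%, within the range 10% to 55%.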

Compound 3, a percentage reported as inhibition, at one concentration (the size of the read-out at that concentration, not a potency): 72.3%
Beside the measured number, compound 3's estimate is 42.3 percentage points below it; measured number above the stated range.
By their numbers in this assay, from the lowest: compound 2; then compound 1; then compound 3.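

In this assay, within the data shown here, swapping phenyl for 3-chloro-2-methylphenyl on the sulfonyl sulfur gives a number 61 percentage points higher from compound 2 to compound 3 (beyond the scatter) and shows that this position can gain a great deal from groups other than the one in compound 1. Replacing 4-(tert-butyl)phenyl with the same ring gives a number 21.2 percentage points higher from compound 1 to compound 3 (beyond the scatter) and so shows that the choice of substituted ring matters, not merely the presence of a substituent. No supporting evidence here accounts for either gain.

The compounds shown leave open whether the chlorine, the methyl or the two together account for the higher number. They also leave open how the read-out would respond to an amine or a carboxylic acid on this ring, or to changes elsewhere in the shared core.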